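The source may hold more compounds than are shown below. What is called first, only, known or untested is meant among the compounds shown, and "the series" means these compounds.

Measured in a functional assay on HepG2 cells (Homo sapiens) for antiproliferative activity, read by MTT assay; a higher number here means a weaker inhibitor, a lower number a stronger inhibitor:
- compound 1 `Nc1c(C(=O)N/N=C/c2ccccc2)oc2nc(-c3ccccc3)cc(C(F)(F)F)c12`: 13100 nM
- compound 2 `CNC(=O)c1oc2nc(-c3ccccc3)cc(C(F)(F)F)c2c1N`: 41200 nM
- compound 3 `Nc1c(C(=O)N/N=C/c2ccccc2)oc2nc(-c3cccs3)cc(C(F)(F)F)c12`: 9900 nM

Compound 3, at 9900 nM, lies within the scatter of compound 1, while compound 2 gives a clearly higher number than compound 3.

The next compound, compound 4 `CNC(=O)c1oc2nc(-c3cccs3)cc(C(F)(F)F)c2c1N`, differs from compound 3 at one place: one carbon atom in place of a group of 8 heavy atoms (7 carbon, 1 nitrogen; one six-membered aromatic ring of carbon only), on an amide-type nitrogen. The same exchange has been measured once with phenyl on the core: a 3.1-fold higher number from compound 1 to compound 2 (0.50 log units; beyond the scatter), a modest step beyond the scatter. The other measured step, thiophen-2-yl in place of phenyl, is a 1.3-fold lower number from compound 1 to compound 3 (0.12 log units; within the scatter), within the scatter, so the two parent compounds read alike in this assay. A step of similar size towards a higher number, meaning weaker inhibition, is therefore expected in this assay. Among the measured compounds shown here, this expectation rests on a single pair, with compound 2 at 41200 nM as its only evidence.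

The expected step is a 3.1-fold higher number from compound 3 to compound 4 (0.50 log units; beyond the scatter). For compound 4 the estimated value is 31000 nM, with an expected range of 15000 nM to 62000 nM.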

Compound 4, half-maximal inhibitory concentration: 12300 nM
Compound 4: middle estimate off by 2.5-fold (0.40 log units), on the high side; the whole stated range lies above it.
By their numbers in this assay, from the lowest: compounds 3, 4 and 1 (each within the scatter of the next); then compound 2.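

With thiophen-2-yl on the core, methyl in place of the larger group on the amide-type nitrogen gives a 1.2-fold higher number from compound 3 to compound 4 (0.09 log units; within the scatter) in this assay, so this exchange does not always produce a step beyond the scatter. With methyl on that nitrogen, thiophen-2-yl in place of phenyl on the aromatic carbon gives a 3.3-fold lower number from compound 2 to compound 4 (0.52 log units; beyond the scatter), although the same exchange did not separate the two parent compounds. A dependence of either exchange on the other cannot be claimed, as the paired steps remain too close: the same change on two cores in this assay, a 3.1-fold higher number (0.50 log units; beyond the scatter) from compound 1 to compound 2 and a 1.2-fold higher number (0.09 log units; within the scatter) from compound 3 to compound 4, 2.5-fold (0.40 log units) apart, within the scatter of two such steps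

Still open, going by these compounds, is whether the amide-type nitrogen accepts an amine-bearing chain or a longer alkyl chain with a similarly small step. On these data alone, it is also open whether a pyridyl group on the aromatic carbon would read like phenyl or thiophen-2-yl.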